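Trading an acid for an alcohol on the pyrazole side chain

The compounds below may be only part of what the source reports. "The series", "measured", "known", "first", "only" and "open" are said of these compounds alone.

Of the compounds shown here, two have been measured so far in an assay on isolated protein for inhibition of methionine--tRNA ligase, cytoplasmic (Homo sapiens); on this read-out lower numbers stand for stronger inhibition and higher numbers for weaker inhibition. Compound 1, `O=C(O)Cn1nc(C(=O)O)cc1-c1ccc(-c2ccc(Cl)cc2Cl)cc1`, carries a carboxy group on the chain that hangs from the ring nitrogen and a second carboxy group on the ring itself; in this assay compound 1 gives 100000 nM, the highest of the two numbers recorded. Compound 2, `Clc1ccc(-c2ccc(-c3cc(-n4cnnn4)nn3-c3cccnc3)cc2)c(Cl)c1`, gives 10600 nM in this assay, a lower number than compound 1, and the gap between the two lies beyond the usual scatter. Neither compound shows strong inhibition.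

Compound 3, `O=C(O)c1cc(-c2ccc(-c3ccc(Cl)cc3Cl)cc2)n(CCO)n1`, has not yet been measured in this assay. It differs from compound 1 in one place: hydroxymethyl in place of carboxy on a saturated chain carbon bound to an aromatic nitrogen. Among the measured compounds shown here, no measured pair in this set isolates such a change, so there is no direct precedent to lean on. Given that compound 1 sits at 100000 nM, the author expects a step from compound 1 to compound 3 of a 2.0-fold lower number from compound 1 to compound 3 (0.30 log units; within the scatter) in this assay, toward a lower number, though the shift could also stay within the scatter. For compound 3 the estimate is 50000 nM, with a range from 10000 nM to 150000 nM.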

Compound 3, half-maximal inhibitory concentration: > 100000 nM
Compound 3 ended at the assay's limit (the forecaster's own chance of this, stated with the estimate: 40%); at least 2.0-fold (0.30 log units) between middle value and limit.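

In this assay compound 3 gives > 100000 nM, and this is a limit of the assay, not a number. Among the compounds shown here, the step reads a number no lower from compound 1 to compound 3 (the limit leaves the size open), so hydroxymethyl in place of carboxy on a saturated chain carbon bound to an aromatic nitrogen brought no measurable gain in inhibition, which no earlier pair could show, although how far the number moved cannot be read. The pair therefore marks this chain only as a place where the change did not bring the number down, and any further weakening remains unquantified: the limit of > 100000 nM in this assay, at which 1 of the 3 values shown sits.

The compounds shown leave open whether an amine, a methyl ester or a longer chain in place of the carboxymethyl group would bring the number down in this assay. They also leave open what happens when the carboxy group on the ring is replaced by a primary amide while the 2-hydroxyethyl chain stays in place, and so whether any change on the core of compound 3 can lift inhibition from the weak end of this read-out.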